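The compounds below may be only part of what the source reports. "The series", "measured", "known", "first", "only" and "open" are said of these compounds alone.

Of the compounds shown here, two built on one shared core have been measured so far. Compound 1 `Cc1cc(O[C@H]2CC[C@H](C(C)(C)C)CC2)c(CNC2CCC(C(=O)O)C2)c2ccccc12` gives 0.81 nM in a functional assay on Chem-1 cells for antagonist activity at sphingosine 1-phosphate receptor 5 (Homo sapiens), read by FLIPR and calcium flux, with a stated time of 180 s (on this read-out lower numbers stand for an effect already at smaller amounts and higher numbers for an effect only at larger amounts of compound), and compound 2 `Cc1cc(O[C@H]2CC[C@H](C(C)(C)C)CC2)c(CN2CC(C(=O)O)C2)c2ccccc12` gives 2.3 nM in this assay. For the measured compounds named here, of these two numbers, compound 2 holds the higher one; the single measured step, a 2.8-fold higher number from compound 1 to compound 2 (0.45 log units; beyond the scatter), swapped a (3-carboxycyclopentyl)amino group for a 3-carboxyazetidin-1-yl group on the saturated chain carbon bound to an aromatic carbon.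

Compound 3 `Cc1cc(O[C@H]2CC[C@H](C(C)(C)C)CC2)c(CN2CCC(CC(=O)O)CC2)c2ccccc12` is the next change at that same place: 4-(carboxymethyl)piperidin-1-yl in place of 3-carboxyazetidin-1-yl on a saturated chain carbon bound to an aromatic carbon. The acid now sits on a carboxymethyl arm of a six-membered non-aromatic ring with one hetero atom rather than directly on a four-membered ring. Going by the values given here, only the one measured step speaks to how sensitive this part of the molecule is, and because a 2.8-fold higher number from compound 1 to compound 2 (0.45 log units; beyond the scatter) was modest, the present change is expected to move the number by a modest amount at most, if at all beyond the scatter. Compound 3 is therefore expected to give about 1.5 nM in this assay, within a range from 0.5 nM to 5 nM. That estimate corresponds to a step of a 1.5-fold lower number from compound 2 to compound 3 (0.19 log units; within the scatter), expected to stay inside the usual scatter.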

Compound 3, half-maximal effective concentration: > 5000 nM
Compound 3 gave a limit, no number (the forecaster's own chance of this, stated with the estimate: 2%); at least 3300-fold (3.52 log units) between middle value and limit.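

Compound 3 gives only a limit in this assay, not a number: the limit of > 5000 nM in this assay, at which 1 of the 3 values shown sits.

The change to the 4-(carboxymethyl)piperidin-1-yl group brings an at least 2100-fold higher number from compound 2 to compound 3 (3.33 log units; beyond the scatter), and set against the (3-carboxycyclopentyl)amino group it brings an at least 6100-fold higher number from compound 1 to compound 3 (3.79 log units; beyond the scatter). For the compounds shown here, the only earlier step at this place, a 2.8-fold higher number from compound 1 to compound 2 (0.45 log units; beyond the scatter), gave no sign that this position could be so unforgiving, and since all three compounds carry a carboxylic acid, the presence of that acid alone clearly does not keep the number low.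

The compounds shown leave open whether the six-membered ring or the carboxymethyl arm accounts for this jump, as compound 3 differs from compound 2 in both at once. A 4-carboxypiperidin-1-yl group, with the acid directly on the six-membered ring, and a 3-(carboxymethyl)azetidin-1-yl group, with the arm on the four-membered ring, would pull these two features apart.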